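The compounds below may be only part of what the source reports. "The series", "measured", "known", "first", "only" and "open" are said of these compounds alone.

In an assay on isolated protein (Cavia porcellus) with Sigma non-opioid intracellular receptor 1 (Homo sapiens) as the target, read by radioligand binding (a lower number here means a stronger inhibitor, a higher number a weaker inhibitor), compound 2, `O=c1cc(-c2ccccc2Cl)oc2ccc(OCCCCCCN3CCC(O)CC3)cc12`, gives 29 nM. Compound 1, `O=c1cc(-c2ccccc2)oc2cccc(OCCCCN3CCC(O)CC3)c12`, gives 177 nM in this assay, so compound 2 has the lower of the two numbers, and the gap between them lies beyond the usual scatter. Compound 3, `O=c1cc(C2CCCCC2)oc2ccc(OCCCCCCN3CCC(O)CC3)cc12`, has not yet been measured; it differs from compound 2 by cyclohexyl in place of 2-chlorophenyl on an aromatic carbon. Going by the values given here, no measured pair shows a change of this kind, so its effect is uncertain. Compound 3 is expected to give 40 nM, between 12 nM and 130 nM. The expected step of a 1.4-fold higher number from compound 2 to compound 3 (0.14 log units; within the scatter) is a slight weakening, not clearly beyond the scatter.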

Compound 3, half-maximal inhibitory concentration: 46 nM
Compound 3: the middle estimate sits 1.2-fold (0.06 log units) below what was measured; low and high end bracket the measured number.
By their numbers in this assay, from the lowest: compounds 2 and 3 (each within the scatter of the next); then compound 1.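

The change of cyclohexyl in place of 2-chlorophenyl, on the aromatic carbon next to the ring oxygen, gives a 1.6-fold higher number from compound 2 to compound 3 (0.20 log units; within the scatter) in this assay. In this one pair, then, the aromatic ring with its chlorine can give way to a non-aromatic carbon ring without a change that can be told apart from the scatter. Nothing at hand explains this result. From the compounds shown here alone, whether a methyl group or a carboxylic acid at this place would leave the number equally unmoved stays open.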